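The source may report more compounds than this note shows. Statements on the series, on what has been measured and on what is new or still open speak of the compounds shown alone.

In a functional assay on SGC-7901 cells (Homo sapiens) for cytotoxicity, read by sulforhodamine B assay, with a stated time of 72 h (a lower number here means a stronger inhibitor, a higher number a weaker inhibitor), three compounds sharing one core have numbers. Compound 1 `C=C1C(=O)O[C@@H]2CC(C)=C([C@@H](C)CCCOC(C)=O)[C@@H](OC(=O)CN3CCCCC3)[C@H]12` gives 11500 nM and compound 3 `C=C1C(=O)O[C@@H]2CC(C)=C([C@@H](C)CCCOC(C)=O)[C@@H](OC(=O)c3ccccc3F)[C@H]12` gives 19300 nM, which is a 1.7-fold higher number from compound 1 to compound 3 (0.22 log units; within the scatter). Compound 2 `C=C1C(=O)O[C@@H]2CC(C)=C([C@@H](C)CCCOC(C)=O)[C@@H](OC(=O)COc3cccc(C(C)=O)c3)[C@H]12` gives 46100 nM, which is a 4.0-fold higher number from compound 1 to compound 2 (0.60 log units; beyond the scatter). Compound 1 therefore sits level with compound 3 and clear of compound 2. Compound 4 `C=C1C(=O)O[C@@H]2CC(C)=C([C@@H](C)CCCOC(C)=O)[C@@H](OC(=O)c3cccc(F)c3)[C@H]12` keeps the core of compound 1 and differs from it by 3-fluorophenyl in place of (piperidin-1-yl)methyl on a carbonyl carbon, with 3-fluorophenyl in place of (piperidin-1-yl)methyl on a carbonyl carbon. The closest guide is compound 3, which carries 2-fluorophenyl there and showed a 1.7-fold higher number from compound 1 to compound 3 (0.22 log units; within the scatter). A similar small rise, not beyond the scatter, is expected, and the estimated step is a 1.7-fold higher number from compound 1 to compound 4 (0.22 log units; within the scatter). Compound 4 is estimated at 19000 nM, within an expected range of 9000 nM to 42000 nM.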

Compound 4, half-maximal inhibitory concentration: 12900 nM
The estimate for compound 4 lay 1.5-fold (0.17 log units) above the measured number; low and high end bracket the measured number.
By their numbers in this assay, from the lowest: compounds 1, 4 and 3 (each within the scatter of the next); then compound 2.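

In this assay, 3-fluorophenyl on the carbonyl carbon matches the (piperidin-1-yl)methyl group of compound 1 (a 1.1-fold higher number from compound 1 to compound 4 (0.05 log units; within the scatter)) within the scatter. The fluorine's placement on the phenyl ring makes no readable difference between the two fluorophenyl esters (a 1.5-fold lower number from compound 3 to compound 4 (0.17 log units; within the scatter)). The 3-fluorophenyl ester also stands clear of the (3-acetylphenoxy)methyl ester (a 3.6-fold lower number from compound 2 to compound 4 (0.55 log units; beyond the scatter)), as the 2-fluorophenyl ester did. No supporting data explain these steps. From the compounds shown here alone, whether 4-fluorophenyl, unsubstituted phenyl or a chlorine in place of the fluorine would stay at this level remains open.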